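Dropping the Chloro Group: Compound 3 to Compound 4

The source may report more compounds than this note shows. Statements on the series, on what has been measured and on what is new or still open speak of the compounds shown alone.

Compound 1 `Cc1nnc(Sc2c(C)oc3ccccc3c2=O)o1`: in a functional assay on LM7 cells (Homo sapiens) for cytotoxicity, read by MTT assay, with a stated time of 72 h (a higher number here means a weaker inhibitor, a lower number a stronger inhibitor), compound 1 gives only the assay limit > 50000 nM.
Compound 2 `Cc1nnc(SCc2cc(=O)c3ccccc3o2)s1`: in this assay compound 2 gives only the assay limit > 25000 nM.
Compound 3 `Cc1nnc(SCc2cc(=O)c3cc(Cl)ccc3o2)o1`: in this assay compound 3 gives only the assay limit > 25000 nM.

Every value here is a limit rather than a number: the cells survived the highest concentration tested, so no concentration for half-maximal inhibition could be read. Compound 3 stands at the limit of > 25000 nM in this assay, at which 2 of the 3 values shown sit, which is where most of the measured compounds sit. The remaining compound sits at the limit of > 50000 nM in this assay, at which 1 of the 3 values shown sits. Among the measured compounds shown here, because all three values are limits, no ordering among the compounds can be drawn, and no measured step exists to lean on.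

Compound 4 `Cc1nnc(SCc2cc(=O)c3ccccc3o2)o1` differs from compound 3 by hydrogen in place of chloro on an aromatic carbon. The step from compound 3 to compound 4 is expected to be none beyond the scatter, as a step that the limit leaves unreadable from compound 3 to compound 4, with compound 4 most likely also reporting only a limit. The estimate for compound 4 in this assay is 40000 nM, within a range from 20000 nM to 100000 nM.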

Compound 4, half-maximal inhibitory concentration: > 25000 nM
Compound 4 was reported as a limit; the forecaster's own chance of this, stated with the estimate: 85%; the middle value is on the limit's open side.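

No new step can be read: in this assay compound 2, compound 3 and compound 4 all stand as limits, which leaves their differences unreadable. The compounds shown leave open whether any of them reaches half-maximal inhibition in this assay at any concentration.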